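The compounds below may be only part of what the source reports. "The series", "measured", "known", "first", "only" and "open" are said of these compounds alone.

Measured compounds in a functional assay on HepG2 cells (Homo sapiens) for cytotoxicity, read by MTT assay, with a stated time of 48 h; on this read-out lower numbers stand for stronger inhibition and higher numbers for weaker inhibition:
compound 1, `CCCCCCCCCCCCCCCCCCNC(=O)[C@@H](N)[C@@H](C)O`, 44500 nM
compound 2, `CCCCCCCCCCCCNC(=O)[C@@H](NC(=O)c1cc2ccccc2o1)[C@@H](C)O`, 22900 nM
compound 3, `CCCCCCCCCCCCCCNC(=O)[C@@H](NC(=O)/C=C/c1ccccc1)[C@@H](C)O`, 150000 nM

Among these three, compound 1 stands second highest. Its number and that of compound 2 lie within the usual scatter of each other, so no order between them can be claimed, while compound 3 lies beyond the scatter above compound 1. Compound 4, `CCCCCCCCCCCCCCCCCCNC(=O)[C@@H](NC(=O)c1nccc2ccccc12)[C@@H](C)O`, has not yet been measured. It differs from compound 1 by (isoquinolin-1-yl)carbonyl in place of hydrogen on an amine nitrogen. Among the compounds with values here, no step between two measured compounds isolates this change; the amine-acylated compounds 2 and 3 also carry shorter chains and fall on either side of compound 1. A step of no more than modest size, possibly downward, is therefore expected; the step from compound 1 to compound 4 is estimated at a 1.5-fold lower number from compound 1 to compound 4 (0.17 log units; within the scatter). Compound 4 is expected to give about 30000 nM, in the range 8000 nM to 120000 nM.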

Compound 4, half-maximal inhibitory concentration: 96900 nM
Beside the measured number, compound 4's estimate is 3.2-fold (0.51 log units) below it, and the stated range covers the measured number.
By their numbers in this assay, from the lowest: compounds 2 and 1 (each within the scatter of the next); then compounds 4 and 3 (each within the scatter of the next).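

Within the data shown here, on the shared core, in this assay, (isoquinolin-1-yl)carbonyl in place of hydrogen on an amine nitrogen gives the first single-change reading at this position (a 2.2-fold higher number from compound 1 to compound 4 (0.34 log units; beyond the scatter)). This modest step runs towards weaker inhibition, so this acylation does not strengthen inhibition here. No measurement shown accounts for the step.

Going by these compounds, whether a plain acetyl or benzoyl group on the same nitrogen would move the number in the same direction remains open. So does whether (isoquinolin-1-yl)carbonyl would give a similar step on a shorter chain.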